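The source may report more compounds than this note shows. Statements on the series, on what has been measured and on what is new or still open speak of the compounds shown alone.

In an assay on HEK293 cells for displacement of a labelled ligand from NPC1-like intracellular cholesterol transporter 1 (Homo sapiens) (on this read-out higher numbers stand for weaker inhibition and lower numbers for stronger inhibition), three compounds sharing one core have been measured. Compound 1 `CC(C)(C)OC(=O)NCCNC(=O)CN1CN(c2ccccc2)C2(CCN(C(=O)c3ccc(C(C)(C)C)cc3)CC2)C1=O` gives 10900 nM, compound 2 `CC(C)(C)c1ccc(C(=O)N2CCC3(CC2)C(=O)N(CC(=O)N2CCN(S(C)(=O)=O)CC2)CN3c2ccccc2)cc1` gives 19000 nM, and compound 3 `CC(C)(C)OC(=O)NC1CCCN(C(=O)CN2CN(c3ccccc3)C3(CCN(C(=O)c4ccc(C(C)(C)C)cc4)CC3)C2=O)C1` gives 4200 nM, the lowest of the three numbers; compound 1 stands nearest to it and compound 2 furthest, both gaps beyond the scatter. Among the compounds with values here, the only step between two compounds that differ in one place, a 1.7-fold higher number from compound 1 to compound 2 (0.24 log units; within the scatter), concerns a different replacement from the one considered here. Compound 4 `CC(C)(C)OC(=O)NCC1CCCN(C(=O)CN2CN(c3ccccc3)C3(CCN(C(=O)c4ccc(C(C)(C)C)cc4)CC3)C2=O)C1` differs from compound 3 by ((tert-butoxycarbonyl)amino)methyl in place of (tert-butoxycarbonyl)amino on a saturated ring carbon. Within the data shown here, no measured step bears on this change: compound 1 and compound 3 carry related groups, but they are not a single-change pair, so their two values show only that compound 3 sits lower. The step from compound 3 to compound 4 is therefore expected to remain within the scatter, a 1.2-fold higher number from compound 3 to compound 4 (0.08 log units; within the scatter), with no clear direction. Compound 4 is estimated to give 5000 nM in this assay, expected to fall between 2000 nM and 13000 nM.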

Compound 4, half-maximal inhibitory concentration: 9500 nM
Beside the measured number, compound 4's estimate is 1.9-fold (0.28 log units) below it, within the range that was stated.
By their numbers in this assay, from the lowest: compound 3; then compounds 4, 1 and 2 (each within the scatter of the next).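

In this assay, within the data shown here, the change on this saturated ring carbon gives a 2.3-fold higher number from compound 3 to compound 4 (0.35 log units; beyond the scatter) and is the first single-change reading at this position. It shows that the position is sensitive to a small change: ((tert-butoxycarbonyl)amino)methyl weakens inhibition modestly relative to (tert-butoxycarbonyl)amino, although the counts of hydrogen-bond donors and acceptors stay the same. No measurement available here accounts for this difference.

The compounds shown leave open whether a longer chain, such as ((tert-butoxycarbonyl)amino)ethyl, on the same ring carbon would extend this modest trend or reverse it. They also leave open whether the tert-butoxycarbonyl group is needed at all, which a free primary amine at this position would test.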